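This account rests on a few compounds, and the source may have more. Where it says the series, first, only, none or still open, it means among the compounds named here.

Measured so far:
compound 1 `COc1ccc(-n2cnc3cnc(-c4ccc(F)cc4C)cc32)cn1`, 70 nM
compound 2 `COc1ccc(-n2cnc3cnc(-c4ccc(F)cc4C)cc32)nc1`, 30 nM
compound 3 `COc1cnc(-n2cnc3cnc(-c4ccc(F)cc4C)cc32)cn1`, 3700 nM

In a functional assay on HL-60 cells (Homo sapiens) for activation, read by flow cytometry, with a stated time of 4 days (on this read-out higher numbers stand for an effect only at larger amounts of compound and lower numbers for an effect already at smaller amounts), compound 3 gives the highest of the three numbers: a 53-fold higher number from compound 1 to compound 3 (1.72 log units; beyond the scatter) and a 120-fold higher number from compound 2 to compound 3 (2.09 log units; beyond the scatter), while a 2.3-fold lower number from compound 1 to compound 2 (0.37 log units; beyond the scatter). Compound 4 `Cc1cc(F)ccc1-c1cc2c(cn1)ncn2CC1CC1` differs from compound 3 as follows: cyclopropylmethyl in place of 5-methoxypyrazin-2-yl on an aromatic nitrogen. Among the compounds with values here, no measured step bears directly on this change; the three steps only swap one methoxy-substituted six-membered aromatic ring for another, and they show that this position moves the read-out strongly. Because compound 3 stands at 3700 nM, an improvement is expected but its size is uncertain. Compound 4 is estimated at 1000 nM, range 100 nM to 10000 nM, which means an expected step of a 3.7-fold lower number from compound 3 to compound 4 (0.57 log units; beyond the scatter).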

Compound 4, half-maximal effective concentration: > 30000 nM
Compound 4: no number, only a limit; the forecaster's own chance of this, stated with the estimate: 15%; at least 30-fold (1.47 log units) between middle value and limit.
By their numbers in this assay, from the lowest: compound 2; then compound 1; then compound 3. At a limit, above all of these: compound 4.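

In this assay compound 4 gives only a limit of the assay, not a number: the limit of > 30000 nM in this assay, at which 1 of the 4 values shown sits. Cyclopropylmethyl on the aromatic nitrogen gives an at least 8.1-fold higher number from compound 3 to compound 4 (0.90 log units; beyond the scatter), an at least 1000-fold higher number from compound 2 to compound 4 (3.00 log units; beyond the scatter) and an at least 420-fold higher number from compound 1 to compound 4 (2.63 log units; beyond the scatter). The earlier steps shown here only exchanged methoxy-substituted six-membered aromatic rings, whereas this change shows that a small non-aromatic ring of carbon only does not keep a measurable read-out at this position.

The compounds shown do not separate the absence of the aromatic ring from the absence of the methoxy group or the hydrogen-bond acceptors. An unsubstituted phenyl or a 2-methoxyethyl chain on the same nitrogen would bear on that question.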